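Pyridin-4-yl for pyridin-2-yl: note toward compound 4

The source may hold more compounds than are shown below. What is called first, only, known or untested is meant among the compounds shown, and "the series" means these compounds.

Compound 1 `CNC(=O)c1cc(Oc2ccc(/C=C/c3ccccn3)cc2)ccn1` gives 21600 nM in a functional assay on HepG2 cells (Homo sapiens) for antiproliferative activity, read by CCK-8 assay, with a stated time of 48 h (on this read-out lower numbers stand for stronger inhibition and higher numbers for weaker inhibition), the lowest number of the three measured compounds, though compound 2 `COc1ccc(CNC(=O)c2cc(Oc3ccc(/C=C/c4ccccn4)cc3)ccn2)cc1` gives 26000 nM and compound 3 `O=C(NC1CC1)c1cc(Oc2ccc(/C=C/c3ccccn3)cc2)ccn1` gives 31000 nM, both within the scatter of compound 1. All steps measured so far sit on the amide side of the shared core: a 1.2-fold higher number from compound 1 to compound 2 (0.08 log units; within the scatter), a 1.4-fold higher number from compound 1 to compound 3 (0.16 log units; within the scatter), a 1.2-fold higher number from compound 2 to compound 3 (0.08 log units; within the scatter). None of them is beyond the scatter.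

Compound 4 `CNC(=O)c1cc(Oc2ccc(/C=C/c3ccncc3)cc2)ccn1` differs from compound 1 at the other end of the molecule: pyridin-4-yl in place of pyridin-2-yl on a double-bonded chain carbon bound to a double-bonded chain carbon. For the measured compounds named here, no measured step touches this part of the structure, so the amide-side steps bear on it only indirectly; what they show is that the numbers in this assay have clustered tightly across three variations of this series. Going by the values given here, with no direct precedent, no step beyond the scatter is expected in this assay in either direction, and the estimate is anchored at compound 1. The estimated step from compound 1 to compound 4 is no change at the digits printed from compound 1 to compound 4 (within the scatter). Compound 4 is expected to give 21600 nM, within 8000 nM to 60000 nM.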

Compound 4, half-maximal inhibitory concentration: 18200 nM
Estimate against measurement, compound 4: 1.2-fold (0.07 log units) above, and the stated range covers the measured number.
By their numbers in this assay, from the lowest: compounds 4, 1, 2 and 3 (each within the scatter of the next).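

In this assay, for the compounds shown here, pyridin-4-yl in place of pyridin-2-yl on a double-bonded chain carbon bound to a double-bonded chain carbon gives a 1.2-fold lower number from compound 1 to compound 4 (0.07 log units; within the scatter), the first reading at this end of the molecule. The two compounds have the same atoms, joined differently, and this change of ring attachment does not separate them in this read-out. This end, like the amide side, has so far shown no step beyond the scatter, although a single pair tests it, and nothing available offers an explanation for the result.

From the compounds shown here alone, it remains open whether pyridin-3-yl or a plain phenyl ring on the same chain carbon would give a step beyond the scatter. Also open, going by these compounds, is whether a larger replacement at this end, such as a quinolin-4-yl group or a morpholine-bearing pyridine, would do so.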